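The compounds below may be only part of what the source reports. "The series", "measured", "known", "first", "only" and "open" are said of these compounds alone.

Compound 1 `N#CC1=C(N)Oc2c(c3nc4ccccc4nc3c3ccccc23)C12C(=O)N(Cc1cnnn1-c1ccc(Br)cc1)c1ccccc12`: in a functional assay on HCT-116 cells (Homo sapiens) for antiproliferative activity, read by MTT assay, with a stated time of 48 h (a higher number here means a weaker inhibitor, a lower number a stronger inhibitor), compound 1 gives only the assay limit, > 50000 nM.
Compound 2 `N#CC1=C(N)Oc2c(c3nc4ccccc4nc3c3ccccc23)C12C(=O)N(Cc1cnnn1-c1ccc(Cl)c(Cl)c1)c1ccccc12`: in this assay compound 2 likewise gives only a limit, > 50000 nM.
Compound 3 `Cc1cccc(-n2nncc2CN2C(=O)C3(C(C#N)=C(N)Oc4c(N)cc5nc6ccccc6nc5c43)c3ccccc32)c1`: in this assay compound 3 also gives a limit, > 50000 nM.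

Compound 3 therefore stands not at a measured number but at the limit of this assay, together with every other measured compound, as shown by the limit of > 50000 nM in this assay, at which 3 of the 3 values shown sit. For the measured compounds named here, the one step between measured compounds that differ in a single place, a step that the two limits leave unreadable from compound 1 to compound 2, runs between two limits and has no readable size.

Compound 4 `CCc1cccc(C)c1-n1nncc1CN1C(=O)C2(C(C#N)=C(N)Oc3c(N)cc4nc5ccccc5nc4c32)c2ccccc21` differs from compound 3 by 2-ethyl-6-methylphenyl in place of 3-methylphenyl on an aromatic nitrogen. Going by the values given here, no measured step concerns this change, and the measured values give nothing beyond limits to build on. The step of a number no higher from compound 3 to compound 4 (the limit leaves the size open) is accordingly expected to stay unreadable rather than to move in either direction beyond the scatter. Compound 4 is estimated at 50000 nM in this assay, with a range from 20000 nM to 100000 nM, and most likely the assay will again report only a limit for compound 4.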

Compound 4, half-maximal inhibitory concentration: > 50000 nM
Compound 4: a limit, no number; the forecaster's own chance of this, stated with the estimate: 80%; the middle value lies on the limit itself.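

Compound 3 and compound 4 both give only a limit, not a number, so no step can be read between them: the limit of > 50000 nM in this assay, at which 4 of the 4 values shown sit.

The compounds shown leave open how strong any of them really is in this assay, and whether changing the group on the aromatic nitrogen alters that strength at all.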